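The source may hold more compounds than are shown below. What is called first, only, known or untested is meant among the compounds shown, and "the series" means these compounds.

Three compounds share one core and differ only in the aryl group attached to the amide carbonyl. Compound 1 `O=C(/C=C/c1cccc(NC(=O)c2ccccc2Br)c1)c1nc2ccccc2[nH]1` carries a 2-bromophenyl there, and in a functional assay on HCT-116 cells (Homo sapiens) for antiproliferative activity, read by MTT assay, with a stated time of 48 h (on this read-out lower numbers stand for stronger inhibition and higher numbers for weaker inhibition), compound 1 gives 1680 nM. Compound 2 `O=C(Nc1cccc(/C=C/C(=O)c2nc3ccccc3[nH]2)c1)c1ccc(Br)cc1` carries a 4-bromophenyl, and in this assay compound 2 gives 2230 nM. Compound 3 `O=C(Nc1cccc(/C=C/C(=O)c2nc3ccccc3[nH]2)c1)c1cccc(C(F)(F)F)c1` carries a 3-(trifluoromethyl)phenyl, and in this assay compound 3 gives 3360 nM. All three numbers fall within the scatter of one another: a 1.3-fold higher number from compound 1 to compound 2 (0.12 log units; within the scatter), a 1.5-fold higher number from compound 2 to compound 3 (0.18 log units; within the scatter), and a 2.0-fold higher number from compound 1 to compound 3 (0.30 log units; within the scatter). The number of compound 2 therefore cannot be set apart from either of the other two; the three compounds behave as one group on this read-out.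

Compound 4 `COc1cccc(C(=O)Nc2cccc(/C=C/C(=O)c3nc4ccccc4[nH]3)c2)c1` has not yet been measured. It differs from compound 2 in one place: 3-methoxyphenyl in place of 4-bromophenyl on a carbonyl carbon. Every measured step that exchanged the aryl group on this carbonyl carbon stayed within the scatter, so a further exchange at the same place is expected to do the same, and the expected step is a 1.0-fold higher number from compound 2 to compound 4 (0.01 log units; within the scatter), nothing beyond the scatter. Compound 4 is therefore expected to give about 2300 nM in this assay, within a range from 1000 nM to 5500 nM.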

Compound 4, half-maximal inhibitory concentration: 3680 nM
The estimate for compound 4 lay 1.6-fold (0.20 log units) below the measured number; low and high end bracket the measured number.
By their numbers in this assay, from the lowest: compounds 1, 2, 3 and 4 (each within the scatter of the next, the first and the last beyond it).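

Exchanging 4-bromophenyl for 3-methoxyphenyl on this carbonyl carbon brings in a hydrogen-bond acceptor that the leaving group lacks, yet in this assay the result stays within the scatter (a 1.7-fold higher number from compound 2 to compound 4 (0.22 log units; within the scatter)). Methoxy in place of trifluoromethyl on an aromatic carbon also stays within the scatter (a 1.1-fold higher number from compound 3 to compound 4 (0.04 log units; within the scatter)), so neither neighbouring comparison separates compound 4 from the earlier compounds. Going by these compounds alone, what is new is the first step at this position to pass beyond the scatter (a 2.2-fold higher number from compound 1 to compound 4 (0.34 log units; beyond the scatter)): it is modest, and it links the two ends of a series whose neighbouring members cannot be told apart, so the position tolerates these aryl groups without being entirely indifferent to the exchange.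

No measurement shown here explains that modest gap or the closeness of the other numbers. Still open, as far as these compounds go, are whether the gap belongs to the change from bromine to methoxy or to where the group sits on the ring, and how this position answers to a phenyl carrying an amine or a carboxylic acid.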